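Amide aryl swap to pyrimidin-4-yl: compound 2 to compound 3

The source may hold more compounds than are shown below. What is called first, only, known or untested is meant among the compounds shown, and "the series" means these compounds.

Compound 1 `Cc1ccccc1C(=O)Nc1sc2c(c1C(N)=O)CCN(C(=S)Nc1ccccc1Cl)C2` and compound 2 `NC(=O)c1c(NC(=O)c2cccc([N+](=O)[O-])c2)sc2c1CCN(C(=S)Nc1ccccc1Cl)C2` share one core and differ only in the aryl group on the amide carbonyl. In a functional assay on HeLa cells (Homo sapiens) for antiproliferative activity, with a stated time of 24 h (on this read-out lower numbers stand for stronger inhibition and higher numbers for weaker inhibition), compound 1 gives 35300 nM and compound 2 gives 40300 nM. The step of a 1.1-fold higher number from compound 1 to compound 2 (0.06 log units; within the scatter) shows that exchanging one aryl group for another on that carbonyl left the read-out unchanged beyond the scatter. Going by the values given here, compound 2 is one of only two numbers so far, and its gap to compound 1 is within the scatter, so the two compounds are not distinguished.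

Compound 3 `NC(=O)c1c(NC(=O)c2ccncn2)sc2c1CCN(C(=S)Nc1ccccc1Cl)C2` carries the change (pyrimidin-4-yl in place of 3-nitrophenyl on a carbonyl carbon). Among the compounds with values here, no measured step covers an aryl-to-heteroaryl exchange at this carbonyl; the only step that bears on it is the aryl exchange between compound 1 and compound 2, which stayed within the scatter. No step beyond the scatter is therefore expected in this assay, with a wider range to allow for the untested heteroaryl. The expected step is a 1.0-fold lower number from compound 2 to compound 3 (0.00 log units; within the scatter). Compound 3 is estimated at 40000 nM, within a range from 15000 nM to 110000 nM.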

Compound 3, half-maximal inhibitory concentration: > 50000 nM
Compound 3 gave a limit, no number; the forecaster's own chance of this, stated with the estimate: 20%; middle value at least 1.2-fold (0.09 log units) from the limit.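

Compound 3 gives > 50000 nM in this assay, which is a limit and not a number. The steps can be read only as floors, an at least 1.2-fold higher number from compound 2 to compound 3 (0.09 log units; that floor lies within the scatter) and an at least 1.4-fold higher number from compound 1 to compound 3 (0.15 log units; that floor lies within the scatter), so pyrimidin-4-yl on this carbonyl carbon gives no lower number than 3-nitrophenyl or 2-methylphenyl, but these floors do not establish a loss beyond the scatter. Unlike the exchange between the two aryl groups, which left compound 1 and compound 2 with measured numbers, this exchange is the only one shown that reaches the limit of the read-out: the limit of > 50000 nM in this assay, at which 1 of the 3 values shown sits.

Still open, as far as these compounds go, is how far the true value of compound 3 lies past the limit, and so whether this exchange moves the read-out beyond the scatter at all. From the compounds shown here alone, all three compounds carry a six-membered aromatic ring on this carbonyl carbon, so it is also open whether a longer alkyl chain, or a ring bearing an amine or a carboxylic acid, would give a lower number than compound 1 and compound 2.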